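The source may report more compounds than this note shows. Statements on the series, on what has been measured and on what is new or still open speak of the compounds shown alone.

Compound 1 `Cc1nc2c3ccccc3ccc2c2nc3c(ccc4ccccc43)c(-c3cccnc3)c12` gives 156 ug/mL in a functional assay, with a stated time of 90 s; a lower number here means a stronger inhibitor, a higher number a weaker inhibitor.
Compound 2 `COc1ccc(-c2c3ccc4ccccc4c3nc3c2c(C)nc2c4ccccc4ccc32)cc1` gives 176 ug/mL in this assay.
Compound 3 `Cc1nc2c3ccccc3ccc2c2nc3c(ccc4ccccc43)c(-c3cc([N+](=O)[O-])ccc3N)c12` gives 110 ug/mL in this assay.

Compound 3 has the lowest of the three numbers, yet the two steps that lead to it, a 1.4-fold lower number from compound 1 to compound 3 (0.15 log units; within the scatter) and a 1.6-fold lower number from compound 2 to compound 3 (0.20 log units; within the scatter), both lie within the scatter, so no order among the three can be claimed. Compound 4 `Cc1nc2c3ccccc3ccc2c2nc3c(ccc4ccccc43)c(-c3ccccc3Cl)c12` differs from compound 3 in one place: 2-chlorophenyl in place of 2-amino-5-nitrophenyl on an aromatic carbon. Every measured step changes the same position, and each was small: a 1.1-fold higher number from compound 1 to compound 2 (0.05 log units; within the scatter), a 1.4-fold lower number from compound 1 to compound 3 (0.15 log units; within the scatter), a 1.6-fold lower number from compound 2 to compound 3 (0.20 log units; within the scatter). Three different groups at this carbon left the number essentially unchanged, so compound 4 is expected to show no step beyond the scatter: a 1.4-fold higher number from compound 3 to compound 4 (0.13 log units; within the scatter). Compound 4 is therefore estimated at 150 ug/mL, with a range from 90 ug/mL to 250 ug/mL.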

Compound 4, half-maximal inhibitory concentration: 170 ug/mL
The estimate for compound 4 lay 1.1-fold (0.05 log units) below the measured number; the range from low to high includes it.
By their numbers in this assay, from the lowest: compounds 3, 1, 4 and 2 (each within the scatter of the next).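

In this assay 2-chlorophenyl on this aromatic carbon stays within the scatter of all three earlier groups, with a 1.5-fold higher number from compound 3 to compound 4 (0.19 log units; within the scatter) and a 1.0-fold lower number from compound 2 to compound 4 (0.02 log units; within the scatter) and a 1.1-fold higher number from compound 1 to compound 4 (0.04 log units; within the scatter). The new group carries no hydrogen-bond donor or acceptor, so removing those of 2-amino-5-nitrophenyl produced no readable step at this position. No available evidence explains why the number stays so flat here. The compounds shown leave open whether a group without an aromatic ring on this carbon, such as an amine, a carboxylic acid or a longer chain, would move the number beyond the scatter.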